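Working notes: fluoro for methyl, toward compound 3

This account rests on a few compounds, and the source may have more. Where it says the series, first, only, none or still open, it means among the compounds named here.

Two compounds of the series carry numbers in an assay on isolated protein for inhibition of Ephrin type-A receptor 2 (Homo sapiens), read by thermal shift assay, tested at 10 uM; on this read-out lower numbers stand for weaker stabilisation of the target and higher numbers for stronger stabilisation of the target against heat. Compound 1 `Cn1nc(-c2ccccc2)cc1NC(=O)Nc1cc(C(F)(F)F)cc(C(F)(F)F)c1` gives 0.9 degrees C in this assay. Compound 2 `Cc1ccc(-n2nc(C(C)(C)C)cc2NC(=O)Nc2cc(F)cc(F)c2)cc1` gives 1.9 degrees C in this assay. Compound 2 thus stands alongside compound 1: the two numbers lie within the scatter of each other, and neither compound can be placed ahead of the other on this read-out.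

Compound 3 `CC(C)(C)c1cc(NC(=O)Nc2cc(F)cc(F)c2)n(-c2ccc(F)cc2)n1` has not been measured in this assay. It differs from compound 2 in one place: fluoro in place of methyl on an aromatic carbon. Going by the values given here, no pair of measured compounds differs by this change alone; compound 1 and compound 2 differ from each other in several places at once, so nothing in the measured data isolates the effect of this exchange. The change swaps one heavy atom for one heavy atom, with no ring, donor or acceptor involved. The expected step is a number 0.20 degrees C lower from compound 2 to compound 3 (within the scatter), which lies within the scatter and has no clear direction. Compound 3 is accordingly estimated at 1.7 degrees C, with a range from 0.5 degrees C to 3 degrees C.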

Compound 3, shift of the target's melting temperature: 1.9 degrees C
For compound 3 the middle estimate is 0.20 degrees C below the measured one, and the stated range covers the measured number.
By their numbers in this assay, from the lowest: compounds 1, 2 and 3 (each within the scatter of the next).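

Exchanging 4-methylphenyl for 4-fluorophenyl gives no change at the digits printed from compound 2 to compound 3 (within the scatter) in this assay. Going by these compounds alone, this is the first comparison that isolates a single place: compound 1 and compound 2 differ in several places at once, whereas this pair shows that, on this read-out, the position para to a large group does not distinguish fluoro from methyl. Nothing available accounts for the two groups reading alike.

On these data alone, the finding rests on one pair and one exchange of a single heavy atom, so it does not show how far this position tolerates change; whether an amine, a carboxylic acid or a longer chain at the same place would give a step beyond the scatter in this assay remains open. Also open is whether fluoro in place of methyl would read the same way with other groups elsewhere on the shared core, since the only background shown for this exchange is that of compound 2 and compound 3.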